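Cyano in Place of Trifluoromethyl: An Expected Outcome

This account rests on a few compounds, and the source may have more. Where it says the series, first, only, none or still open, it means among the compounds named here.

Compound 1, `Cn1nc(-c2ccccc2)c2c1OC(N)=C(C#N)C2c1cc(F)cc(F)c1`: 6600 nM in a functional assay on NCI-H2122 cells (Homo sapiens) for inhibition, read by microscopy, with a stated time of 10 days; a higher number here means a weaker inhibitor, a lower number a stronger inhibitor
Compound 2, `Cn1nc(-c2ccccc2)c2c1OC(N)=C(C#N)C2c1ccc(C(F)(F)F)cc1`: 4100 nM

Among the compounds with values here, compound 2 has the lower of the two numbers measured so far, but its nearest neighbour, compound 1, lies within the usual scatter, so the two cannot be ranked. Compound 3, `Cn1nc(-c2ccccc2)c2c1OC(N)=C(C#N)C2c1ccc(C#N)cc1`, differs from compound 2 by cyano in place of trifluoromethyl on an aromatic carbon, para to a large group. Within the data shown here, no measured pair shows this change, so in this assay no shift beyond the scatter is expected in either direction. The expected step is a 1.1-fold higher number from compound 2 to compound 3 (0.04 log units; within the scatter). Compound 3 is therefore estimated at 4500 nM, with a range from 1500 nM to 13000 nM.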

Compound 3, half-maximal inhibitory concentration: 5200 nM
The estimate for compound 3 lay 1.2-fold (0.06 log units) below the measured number, within the range that was stated.
By their numbers in this assay, from the lowest: compounds 2, 3 and 1 (each within the scatter of the next).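

In this assay, cyano in place of trifluoromethyl on an aromatic carbon gives a 1.3-fold higher number from compound 2 to compound 3 (0.10 log units; within the scatter), so at this position the two groups cannot be told apart. The larger change, 4-cyanophenyl in place of 3,5-difluorophenyl on a saturated ring carbon, gives a 1.3-fold lower number from compound 1 to compound 3 (0.10 log units; within the scatter), and so also leaves the number within the scatter. Nothing measured here offers an explanation for these results. On these data alone, whether an amine or a carboxylic acid on this aromatic carbon would move the number beyond the scatter remains open. So does the effect of any change elsewhere on the shared core.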